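Nitro in place of hydrogen on the phenyl of compound 3

The source may hold more compounds than are shown below. What is called first, only, known or untested is meant among the compounds shown, and "the series" means these compounds.

Within the data shown here, compound 3 `CC(c1ccc(-c2ccccc2)c(F)c1)c1nnc2n1N=C(c1ccccc1)CS2` gives 6700 nM in a functional assay on Huh-7 cells (Homo sapiens) for inhibition, read by sulforhodamine B assay, with a stated time of 72 h (on this read-out higher numbers stand for weaker inhibition and lower numbers for stronger inhibition), the lowest of the three numbers measured so far. Compound 1 `CC(c1ccc(-c2ccccc2)c(F)c1)c1nnc2n1N=C(c1ccc(OC(F)(F)F)cc1)CS2` carries trifluoromethoxy where compound 3 carries hydrogen. In this assay compound 1 gives 8400 nM, and the step of a 1.3-fold lower number from compound 1 to compound 3 (0.10 log units; within the scatter) lies within the scatter. Compound 2 `COc1ccc2cc(C(C)c3nnc4n3N=C(c3ccc(C(F)(F)F)cc3)CS4)ccc2c1` differs from compound 3 in more than one place. In this assay compound 2 gives 14800 nM, which stands beyond the scatter from compound 3.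

Compound 4 `CC(c1ccc(-c2ccccc2)c(F)c1)c1nnc2n1N=C(c1ccc([N+](=O)[O-])cc1)CS2` is the next member of the series. Its change from compound 3: nitro in place of hydrogen on an aromatic carbon.

Of the measured steps, only a 1.3-fold lower number from compound 1 to compound 3 (0.10 log units; within the scatter) concerns a group on that aromatic carbon, and it was within the scatter. Among the measured compounds shown here, nothing else measured touches this part of the structure; no nitro compound has been run. On that footing, the step from compound 3 to compound 4 is expected to be no larger than the scatter, with no direction to call: a 1.0-fold higher number from compound 3 to compound 4 (0.02 log units; within the scatter).

For the measured compounds named here, compound 4 is therefore estimated at 7000 nM in this assay, with a range from 2500 nM to 20000 nM; the range is kept wide because the single bearing step a 1.3-fold lower number from compound 1 to compound 3 (0.10 log units; within the scatter) tells little about a nitro group.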

Compound 4, half-maximal inhibitory concentration: 4300 nM
Beside the measured number, compound 4's estimate is 1.6-fold (0.21 log units) above it, within the range that was stated.
By their numbers in this assay, from the lowest: compounds 4, 3, 1 and 2 (each within the scatter of the next, the first and the last beyond it).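

Nitro is a third group on the aromatic carbon para to a large group, after hydrogen and trifluoromethoxy, and in this assay a 1.6-fold lower number from compound 3 to compound 4 (0.19 log units; within the scatter) stays within the scatter, as the earlier hydrogen and trifluoromethoxy pair did. The second pair with nitro, a 2.0-fold lower number from compound 1 to compound 4 (0.29 log units; within the scatter), is also printed within the scatter, so none of the three pairs at this position can be separated from repeat measurement, even though the entering nitro brings 3 heavy atoms and 2 hydrogen-bond acceptors in place of a hydrogen atom. The position therefore tolerates all three groups on the shared core in this read-out, a statement limited to compound 1, compound 3 and compound 4, and no supporting measurement is available to explain it.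

On these data alone, whether this flat reading extends to an amine, a carboxylic acid or a longer chain such as an alkoxy chain on the same carbon remains open, as does the effect of moving nitro to another carbon of the phenyl. Compound 2 differs from these three in more than one place, so it cannot show whether the same tolerance holds with a different group on the other side of the core.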